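A few compounds are considered here, and "the series" means these few. Any claim that something is new, unique, unknown or untested is made for them only; others in the source may bear on it.

Of the compounds shown here, three built on a shared core have been measured in a functional assay on A549 cells (Homo sapiens) for cytotoxicity, read by MTT assay, with a stated time of 72 h; a lower number here means a stronger inhibitor, a higher number a weaker inhibitor. Compound 1 `COc1c(OCCCCN2CCN(C)CC2)cc(O)c2c(=O)cc(-c3ccc([N+](=O)[O-])cc3)oc12` gives 3210 nM, and compound 2 `COc1c(OCCCCN2CCN(C)CC2)cc(O)c2c(=O)cc(-c3ccc(F)cc3Br)oc12` gives 2980 nM; the step of a 1.1-fold lower number from compound 1 to compound 2 (0.03 log units; within the scatter) concerns the aryl group alone. Compound 3 `O=c1cc(-c2ccccc2)oc2c(OCCCN3CCCC3)c(OCc3ccccc3)cc(O)c12` gives 4720 nM, the largest of the three numbers, yet its gaps to compound 1 and to compound 2 both lie within the scatter, so the three stand together. Compound 4 `CN1CCN(CCCCOc2c(OCc3ccccc3)cc(O)c3c(=O)cc(-c4ccccc4)oc23)CC1` is not yet measured. It differs from compound 3 by (4-methylpiperazin-1-yl)methyl in place of pyrrolidin-1-yl on a saturated chain carbon, three bonds along the chain from an oxygen on an aromatic ring, which gives it the same chain end as compound 1 and compound 2. Within the data shown here, no measured step touches this part of the molecule; the one step on record changes the aryl group and stays within the scatter, so it offers no direction. Compound 1 carries this chain end and gives 3210 nM, as does compound 2 with 2980 nM, both within the scatter of compound 3. The expected step is therefore a 1.3-fold lower number from compound 3 to compound 4 (0.12 log units; within the scatter), nothing beyond the scatter. Compound 4 is accordingly estimated at 3600 nM, between 1500 nM and 8500 nM.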

Compound 4, half-maximal inhibitory concentration: 2910 nM
Estimate against measurement, compound 4: 1.2-fold (0.09 log units) above, within the range that was stated.
By their numbers in this assay, from the lowest: compounds 4, 2, 1 and 3 (each within the scatter of the next).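

In this assay this position now has a measured step of its own: (4-methylpiperazin-1-yl)methyl in place of pyrrolidin-1-yl on a saturated chain carbon, three bonds along the chain from an oxygen on an aromatic ring, gives a 1.6-fold lower number from compound 3 to compound 4 (0.21 log units; within the scatter) and so shows no effect that can be told from the scatter. Read one bond further out, the same difference is 3-(pyrrolidin-1-yl)propyl to 4-(4-methylpiperazin-1-yl)butyl, so the ring and the chain length change together and this pair cannot separate them. Nothing at hand offers an explanation for this result.

Going by these compounds, it stays open how 3-(4-methylpiperazin-1-yl)propyl or 4-(pyrrolidin-1-yl)butyl would read in this assay on this core. On these data alone, a morpholine or a dimethylamino group at the chain end is equally open.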